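A few compounds are considered here, and "the series" means these few. Any claim that something is new, unique, unknown or untested is made for them only; others in the source may bear on it.

Compound 1 `O=C(NC/C=C\Cn1ccc(=O)[nH]c1=O)c1ccccc1` is the plainest member of the set and defines the shared core. In a functional assay on HEp-2 cells (Homo sapiens) for cytotoxicity, read by MTT assay, with a stated time of 72 h (a higher number here means a weaker inhibitor, a lower number a stronger inhibitor), compound 1 gives only a limit of the assay, > 100000 nM. Compound 2 `Cc1cn(C/C=C\CNC(=O)c2ccccc2)c(=O)[nH]c1=O` carries a methyl on an aromatic carbon of that core; in this assay compound 2 likewise gives only a limit, > 100000 nM. Compound 3 `O=C(NC/C=C\Cn1ccc(=O)[nH]c1=O)c1ccc(F)cc1` instead carries fluoro on an aromatic carbon; in this assay compound 3 also gives only a limit, > 100000 nM. Compound 3 therefore stands at the limit of > 100000 nM in this assay, at which 3 of the 3 values shown sit, with no number of its own.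

The step from compound 3 to compound 4 `Cc1cn(C/C=C\CNC(=O)c2ccc(F)cc2)c(=O)[nH]c1=O` is methyl in place of hydrogen on an aromatic carbon. Going by the values given here, two measured steps bear on it. The change a step that the two limits leave unreadable from compound 1 to compound 2 introduces the same methyl at the same place, and a step that the two limits leave unreadable from compound 1 to compound 3 introduces the fluoro that compound 4 also carries. Neither step can be read, since both ends sit at the limit. Nothing among these compounds suggests that adding the methyl to compound 3 would bring the value down into the readable range, so the step that the limit leaves unreadable from compound 3 to compound 4 is expected to be small or absent. Compound 4 is accordingly estimated at 150000 nM, with a range from 70000 nM to 400000 nM, most probably reported once more only as a limit.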

Compound 4, half-maximal inhibitory concentration: > 100000 nM
Compound 4: no number, only a limit; the forecaster's own chance of this, stated with the estimate: 90%; the middle value is on the limit's open side.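

Neither the step from compound 3 to compound 4 nor the one from compound 2 to compound 4 can be read in this assay, since both ends of each give only a limit: the limit of > 100000 nM in this assay, at which 4 of the 4 values shown sit.

The compounds shown leave open how large the methyl and fluoro steps are, and whether any change to the shared core gives a readable value.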